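This account rests on a few compounds, and the source may have more. Where it says the series, first, only, none or still open, it means among the compounds named here.

Compound 1 `COc1ncnc2c1c(-c1ccccc1)cn2[C@@H]1O[C@H](CO)[C@@H](O)[C@H]1O`: > 20000 nM
Compound 2 `COc1ncnc2c1c(-c1ccco1)cn2[C@@H]1O[C@H](CO)[C@@H](O)[C@H]1O`: 100 nM
Compound 3 `COc1ncnc2c1c(-c1ccsc1)cn2[C@@H]1O[C@H](CO)[C@@H](O)[C@H]1O`: 130 nM

In a functional assay on HL-60 cells (Homo sapiens) for antiproliferative activity, read by XTT assay, with a stated time of 72 h (on this read-out lower numbers stand for stronger inhibition and higher numbers for weaker inhibition), compound 1 reaches only a limit, > 20000 nM, as noted in the limit of > 20000 nM in this assay, at which 1 of the 3 values shown sits. Compound 2 and compound 3 stand together: a 1.3-fold higher number from compound 2 to compound 3 (0.11 log units; within the scatter). Both lie far from compound 1, with an at least 200-fold lower number from compound 1 to compound 2 (2.30 log units; beyond the scatter) and an at least 150-fold lower number from compound 1 to compound 3 (2.18 log units; beyond the scatter). Compound 4 `CNc1ncnc2c1c(-c1ccco1)cn2[C@@H]1O[C@H](CO)[C@@H](O)[C@H]1O` differs from compound 2 by methylamino in place of methoxy on an aromatic carbon. Within the data shown here, no measured step touches this position: the two large steps replace phenyl with furan-2-yl or thiophen-3-yl, and the small one exchanges those two rings. Compound 4 is therefore expected close to compound 2, with a 1.2-fold higher number from compound 2 to compound 4 (0.08 log units; within the scatter), no step beyond the scatter in either direction. For compound 4 the estimate is 120 nM, within 30 nM to 500 nM.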

Compound 4, half-maximal inhibitory concentration: 620 nM
Compound 4: the middle estimate sits 5.2-fold (0.71 log units) below what was measured; measured number outside the range, above it.
By their numbers in this assay, from the lowest: compounds 2 and 3 (each within the scatter of the next); then compound 4. At a limit, above all of these: compound 1.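

In this assay this position proves sensitive: with furan-2-yl kept, methylamino in place of methoxy gives a 6.2-fold higher number from compound 2 to compound 4 (0.79 log units; beyond the scatter). So activity in this series depends on this group on the six-membered aromatic ring as well as on the aromatic ring changed in the earlier steps, though this step is modest. Nothing shown accounts for the step.

Still open, from the compounds shown here alone, is how a plain amine, a dimethylamino group or a longer chain such as ethoxy would fare here. Going by these compounds, whether methylamino has the same effect with thiophen-3-yl in place of furan-2-yl also remains open.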